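The compounds below may be only part of what the source reports. "The series", "measured", "known", "first", "only" and "open" are said of these compounds alone.

Compound 3 `N#Cc1ccc2c(-c3ccc(Cl)cc3)c(S(=O)(=O)c3ccc(F)cc3)cnc2c1` shows, in an ADME assay on microsomes from liver (Homo sapiens) for metabolic stability, tested at 2.5 uM (on this read-out higher numbers stand for fast clearance and lower numbers for slow clearance), a number of 0.01 mL/min, the lowest of the three measured compounds. Compound 2 `O=S(=O)(c1cc(Cl)cc(Cl)c1)c1cnc2cc(F)ccc2c1-c1ccc(Cl)cc1` gives 0.13 mL/min in this assay, and compound 1 `O=S(=O)(c1ccc(F)c(Cl)c1)c1cnc2cc(F)ccc2c1-c1ccc(Cl)cc1` gives 0.39 mL/min. Compound 4 `O=S(=O)(c1ccc(F)cc1)c1cnc2cc(F)ccc2c1-c1ccc(Cl)cc1` differs from compound 3 in one place: fluoro in place of cyano on an aromatic carbon. Within the data shown here, the only measured step, a 3.0-fold lower number from compound 1 to compound 2 (0.48 log units; beyond the scatter), concerns the group on the sulfonyl sulfur, not the fused core, so nothing measured bears directly on this change. Compounds 1 and 2, which both carry fluoro on the core, sit well above compound 3, so compound 4 is expected to move upward, an estimated 10-fold higher number from compound 3 to compound 4 (1.00 log units; beyond the scatter). Compound 4 is therefore estimated at 0.1 mL/min, with a range from 0.03 mL/min to 0.4 mL/min.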

Compound 4, intrinsic clearance in a liver preparation (reported as CLH), per the amount of preparation that the assay uses: 1.23 mL/min
Estimate against measurement, compound 4: 12-fold (1.09 log units) below; measured number above the stated range.
By their numbers in this assay, from the lowest: compound 3; then compound 2; then compound 1; then compound 4.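

In this assay, the group on the core matters a great deal: fluoro in place of cyano gives a 120-fold higher number from compound 3 to compound 4 (2.09 log units; beyond the scatter), far larger than either step at the sulfonyl group. With fluoro on the core, the sulfonyl group also counts, since hydrogen in place of chloro gives a 3.2-fold higher number from compound 1 to compound 4 (0.50 log units; beyond the scatter), and 4-fluorophenyl in place of 3,5-dichlorophenyl gives a 9.5-fold higher number from compound 2 to compound 4 (0.98 log units; beyond the scatter). Nothing measured here gives a reason for these steps. On these data alone, whether a methoxy group, an amide or plain hydrogen at this place would keep the number as low as cyano does remains open. So does whether cyano would have the same effect alongside the chlorinated sulfonyl groups.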